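Nitro for bromo on two related cores: cytotoxicity in MT4 cells

The source may report more compounds than this note shows. Statements on the series, on what has been measured and on what is new or still open speak of the compounds shown alone.

Measured compounds:
- compound 1, `Cc1cc(OCC(=O)Nc2ccc(Br)cc2)nc(Nc2ccc(C#N)cc2)n1`: 930 nM
- compound 2, `Cc1cc(OCC(=O)Nc2ccc([N+](=O)[O-])cc2)nc(Nc2ccc(C#N)cc2)n1`: > 309000 nM
- compound 3, `Cc1cnc(Nc2ccc(C#N)cc2)nc1OCC(=O)Nc1ccc(Br)cc1`: 34700 nM

In an ADME assay on MT4 cells (Homo sapiens) for cytotoxicity, read by MTT assay, with a stated time of 5 days (on this read-out higher numbers stand for lower toxicity in this test and lower numbers for higher toxicity in this test), compound 1 gives 930 nM. Compound 2 is reported only as a limit of the assay, > 309000 nM, and not as a number. Compound 3 gives 34700 nM, the highest of the two plain numbers; set against compound 1 it reads as the less toxic of the two. Compound 1 and compound 3 are built from the same atoms joined differently, and the difference between the two cores is not broken down here.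

Compound 1 and compound 2 differ in one place: nitro in place of bromo on an aromatic carbon. This change made an at least 330-fold higher number from compound 1 to compound 2 (2.52 log units; beyond the scatter), a step given only as a bound because of the limit of > 309000 nM in this assay, at which 1 of the 3 values shown sits.

Compound 4, `Cc1cnc(Nc2ccc(C#N)cc2)nc1OCC(=O)Nc1ccc([N+](=O)[O-])cc1`, has not yet been measured. It differs from compound 3 in the same way: nitro in place of bromo on an aromatic carbon, at the same place, so it is the same change on the other core. Compound 4 is expected to show a 10-fold higher number from compound 3 to compound 4 (1.00 log units; beyond the scatter), resting on the large step seen for compound 2, an at least 330-fold higher number from compound 1 to compound 2 (2.52 log units; beyond the scatter), and on the starting point of compound 3, 34700 nM. Since that starting point already lies high, the result for compound 4 is expected to come out at or beyond the assay limit, estimated at 350000 nM with a range from 100000 nM to 3000000 nM.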

Compound 4, half-maximal cytotoxic concentration: 66300 nM
Compound 4: middle estimate off by 5.3-fold (0.72 log units), on the high side; measured number outside the range, below it.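

Nitro in place of bromo on the other core gave a 1.9-fold higher number from compound 3 to compound 4 (0.28 log units; within the scatter), so in this assay this step stays inside the usual scatter of repeated measurements. The change therefore did not carry over from one core to the other at the size seen first, and the two steps differ: the same change on two cores in this assay, an at least 330-fold higher number (2.52 log units; beyond the scatter) from compound 1 to compound 2 and a 1.9-fold higher number (0.28 log units; within the scatter) from compound 3 to compound 4, at least 170-fold (2.24 log units) apart, beyond the scatter of two such steps. These two pairs show that the size of this step in the series is not fixed across cores, but they do not show why the cores part, and the earlier step is known only as a bound: the limit of > 309000 nM in this assay, at which 1 of the 4 values shown sits.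

The compounds shown leave open how other groups at the same place, such as an amine or a carboxylic acid, would read in this assay on either core. They also leave open whether the same change on a further core would give a step nearer to the large one or to the one within the scatter.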